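A few compounds are considered here, and "the series" means these few. Any claim that something is new, unique, unknown or untested is made for them only; others in the source may bear on it.

Measured so far:
- Compound 1 `CC(Nc1ccccc1Oc1ccc(Cl)cc1)=C1C(=O)CC(c2ccccc2)CC1=O`: 250 nM
- Compound 2 `COc1ccc(Oc2ccccc2NC(C)=C2C(=O)CC(c3ccccc3)CC2=O)cc1`: 140 nM
- Compound 3 `CCOc1ccccc1NC(C)=C1C(=O)CC(c2ccccc2)CC1=O`: 190 nM

In a functional assay on L1210 cells (Mus musculus) for antiproliferative activity, read by cell counting, with a stated time of 96 h (a lower number here means a stronger inhibitor, a higher number a weaker inhibitor), compound 3 gives 190 nM, a value within the scatter of both other compounds. Compound 4 `CC(Nc1ccccc1Oc1ccc(N)cc1)=C1C(=O)CC(c2ccccc2)CC1=O` has not yet been measured. It differs from compound 3 as follows: 4-aminophenyl in place of ethyl on an oxygen on an aromatic ring. In words, 4-aminophenyl stands in place of ethyl on an oxygen on an aromatic ring.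

Two measured steps make a similar exchange, swapping ethyl and a substituted phenyl on that oxygen. They are a 1.3-fold lower number from compound 1 to compound 3 (0.12 log units; within the scatter) and a 1.4-fold higher number from compound 2 to compound 3 (0.13 log units; within the scatter). Changing only the group on that phenyl, methoxy in place of chloro, gave a 1.8-fold lower number from compound 1 to compound 2 (0.25 log units; within the scatter). Among the compounds with values here, all three steps stay within the scatter, although no compound with an amino group has been measured, so this comparison is only indirect. No step beyond the scatter is therefore expected, and the estimated change is a 1.1-fold lower number from compound 3 to compound 4 (0.05 log units; within the scatter). For compound 4 the expected value is 170 nM, with an estimated range from 70 nM to 400 nM.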

Compound 4, half-maximal inhibitory concentration: 40 nM
Beside the measured number, compound 4's estimate is 4.3-fold (0.63 log units) above it; measured number below the stated range.
By their numbers in this assay, from the lowest: compound 4; then compounds 2, 3 and 1 (each within the scatter of the next).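

In this assay, within the data shown here, the earlier swaps on this oxygen stayed within the scatter, but 4-aminophenyl in place of ethyl gives a 4.8-fold lower number from compound 3 to compound 4 (0.68 log units; beyond the scatter) and is the first step at this position to go beyond it. The phenyl ring alone does not account for this: the steps from ethyl to 4-chlorophenyl and 4-methoxyphenyl stayed within the scatter, whereas amino in place of methoxy gives a 3.5-fold lower number from compound 2 to compound 4 (0.54 log units; beyond the scatter) and amino in place of chloro gives a 6.3-fold lower number from compound 1 to compound 4 (0.80 log units; beyond the scatter) on the same ring. No measurement here explains why the amino compound stands apart.

The compounds shown leave open whether this gain is specific to the amino group or would also appear with a hydroxyl, dimethylamino or acetamido group on that ring. They also leave open whether the amino group needs the phenyl ring at all, which an aminoethyl group on the oxygen would test.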